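This account rests on a few compounds, and the source may have more. Where it says the series, first, only, none or still open, it means among the compounds named here.

Compound 1 `COc1cc(/C=C2\CN(C)C/C(=C\c3ccc(Cl)cc3)C2=O)cc(OC)c1` and compound 2 `COc1cc(/C=C2\CN(C)C/C(=C\c3ccc(Br)cc3)C2=O)cc(OC)c1` share one core and differ only in bromo in place of chloro on an aromatic carbon. In a functional assay on HeLa cells (Homo sapiens) for cytotoxicity, read by MTT assay, with a stated time of 24 h (a lower number here means a stronger inhibitor, a higher number a weaker inhibitor), compound 1 gives 11200 nM. In this assay compound 2 gives 5900 nM. That change made a 1.9-fold lower number from compound 1 to compound 2 (0.28 log units; within the scatter). Compound 3 `COc1cc(/C=C2\CN(C)C/C(=C\c3ccc(Cl)cc3)C2=O)cc(OC)c1OC` differs from compound 1 by methoxy in place of hydrogen on an aromatic carbon. For compound 3 the assay returns only a limit, > 20000 nM. This appears as an at least 1.7-fold higher number from compound 1 to compound 3 (0.25 log units; that floor lies within the scatter), its floor set by the limit of > 20000 nM in this assay, at which 1 of the 3 values shown sits. Compound 4 `COc1cc(/C=C2\CN(C)C/C(=C\c3ccc(Br)cc3)C2=O)cc(OC)c1OC` differs from compound 3 by bromo in place of chloro on an aromatic carbon, the same change already seen between compound 1 and compound 2, now on the core that carries the added methoxy. Because a 1.9-fold lower number from compound 1 to compound 2 (0.28 log units; within the scatter) stayed within the scatter, the same change is expected to give only an at least 1.1-fold lower number from compound 3 to compound 4 (0.04 log units; that floor lies within the scatter). Compound 4 is therefore estimated at 18000 nM, with a real chance that the assay again reports only a limit.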

Compound 4, half-maximal inhibitory concentration: 11900 nM
Compound 4: the middle estimate sits 1.5-fold (0.18 log units) above what was measured; the range from low to high includes it.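

Bromo in place of chloro on the core with the added methoxy gives an at least 1.6-fold lower number from compound 3 to compound 4 (0.22 log units; that floor lies within the scatter), and the added methoxy on the bromo core gives a 2.0-fold higher number from compound 2 to compound 4 (0.30 log units; within the scatter). Neither step clearly exceeds the usual scatter, so no firm effect is shown, and whether the bromo step keeps its size on both cores stays unsettled: the same change on two cores in this assay, a 1.9-fold lower number (0.28 log units; within the scatter) from compound 1 to compound 2 and an at least 1.6-fold lower number (0.22 log units; that floor lies within the scatter) from compound 3 to compound 4; the limit leaves it open whether they differ. The added methoxy is equally unsettled: the same change on two cores in this assay, an at least 1.7-fold higher number (0.25 log units; that floor lies within the scatter) from compound 1 to compound 3 and a 2.0-fold higher number (0.30 log units; within the scatter) from compound 2 to compound 4; the limit leaves it open whether they differ.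

The compounds shown leave open what happens with a fluoro or a nitrile in place of the chloro, or with an amine in place of the added methoxy. They also leave open whether any such group would move the number beyond the scatter.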